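The source may hold more compounds than are shown below. What is called first, only, known or untested is meant among the compounds shown, and "the series" means these compounds.

Two macrocyclic, peptide-like compounds have been tested in a functional assay on HG23 cells (Homo sapiens) for cytotoxicity; on this read-out lower numbers stand for higher toxicity in this test and higher numbers for lower toxicity in this test. Compound 1, with the structure `CC(C)C[C@@H]1NC(=O)[C@@H](NC(=O)OC(C)(C)C)Cc2nnc(o2)CNC(=O)CC[C@@H](C=O)NC1=O`, gives a value that is only a limit of the assay, > 100000 nM. Compound 2, with the structure `CC(C)C[C@@H]1NC(=O)[C@@H](NC(=O)OC(C)(C)C)CCc2nnc(o2)CCNC(=O)CC[C@@H](C=O)NC1=O`, likewise returns only a limit, > 100000 nM. Both values therefore sit at the same edge of the test, (the limit of > 100000 nM in this assay, at which 2 of the 2 values shown sit), so nothing separates compound 1 from compound 2 on this read-out, and neither shows measurable toxicity within the tested range.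

Compound 3, with the structure `CC(C)(C)OC(=O)N[C@H]1CCc2nnc(o2)CCNC(=O)CC[C@@H](C=O)NC(=O)[C@H](CC2CCCCC2)NC1=O`, has not yet been measured. It differs from compound 2 in one place: cyclohexyl in place of isopropyl on a saturated chain carbon bound to a saturated ring carbon. Going by the values given here, no measured pair of compounds here shares this change, so there is no directly comparable step to lean on. Compound 2 shows no measurable toxicity at all in this assay, and the step that the limit leaves unreadable from compound 2 to compound 3 is expected to be close to none, within the scatter. Compound 3 is therefore expected at 150000 nM, with a range from 60000 nM to 400000 nM, and most likely it will again be reported only as a limit.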

Compound 3, half-maximal cytotoxic concentration: > 100000 nM
Compound 3: only a limit was reported; the forecaster's own chance of this, stated with the estimate: 80%; the middle value lies beyond the limit too.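

In this assay, compound 3 gives only a limit, > 100000 nM. Going by these compounds alone, no step from compound 2 to compound 3 can be read, because all the values sit at the same edge of the test: the limit of > 100000 nM in this assay, at which 3 of the 3 values shown sit. The compounds shown leave open whether cyclohexyl in place of isopropyl changes toxicity at all, and at what concentration any of them becomes toxic.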